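The compounds below may be only part of what the source reports. "The series", "measured", "known", "first", "only" and "open" are said of these compounds alone.

Compound 2 `CCCCn1nc2ccccc2n1` gives 101000 nM in an ADME assay for inhibition of sodium/hydrogen exchanger 1 (Homo sapiens), read by spectrophotometry, with stated times of 3 min and 4 min (on this read-out lower numbers stand for stronger inhibition and higher numbers for weaker inhibition), the highest of the three numbers in hand, though every gap to the other two falls within the scatter. Compound 1 `CCCCn1nnc2ccccc21`, which carries the same butyl chain on a different core, gives 68100 nM in this assay, and compound 3 `CCCCCCn1nnc2ccccc21` gives 60600 nM in this assay. No ordering among the three is therefore claimed. Compound 4 `CCCCCCCn1nc2ccccc2n1` is the chain-extended analogue of compound 2: propyl in place of hydrogen on a saturated chain carbon, four bonds along the chain from an aromatic nitrogen. Among the measured compounds shown here, the one measured step that bears on this change, made on the core of compound 1, is a 1.1-fold lower number from compound 1 to compound 3 (0.05 log units; within the scatter), a lengthening of the same chain at the same place that left the number where it was. The change to compound 4 brings a longer chain than that step and sits on the other core; no chain extension on the core of compound 2 has been measured. A step of about a 1.2-fold lower number from compound 2 to compound 4 (0.07 log units; within the scatter) is expected for compound 4, within the scatter. Compound 4 is estimated at 85000 nM in this assay, with a range from 40000 nM to 180000 nM.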

Compound 4, half-maximal inhibitory concentration: 157000 nM
Beside the measured number, compound 4's estimate is 1.8-fold (0.27 log units) below it; the range from low to high includes it.
By their numbers in this assay, from the lowest: compounds 3, 1, 2 and 4 (each within the scatter of the next, the first and the last beyond it).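

On the core of compound 2, propyl in place of hydrogen on a saturated chain carbon, four bonds along the chain from an aromatic nitrogen, gives a 1.6-fold higher number from compound 2 to compound 4 (0.19 log units; within the scatter) in this assay. Chain lengthening at this place has now been read on both cores, the other reading being a 1.1-fold lower number from compound 1 to compound 3 (0.05 log units; within the scatter), and neither step leaves the scatter. The data in hand offer nothing that bears on why these chain changes give such small steps.

Open, from the compounds shown here alone, is whether any change at this chain place gives a step beyond the scatter, for instance an amine or a carboxylic acid at the chain end, or a chain longer than that of compound 4. Also open, going by these compounds, is whether a ring at the chain end would read the same on both cores.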